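The source may report more compounds than this note shows. Statements on the series, on what has been measured and on what is new or still open speak of the compounds shown alone.

Working notes on the series. Compound 1 `CCCS(=O)(=O)Nc1cc(F)c(C(=O)c2c[nH]c3ncc(-c4ccc(Cl)cc4)cc23)c(F)c1` gives 139 nM in a functional assay on A-375 cells (Homo sapiens) for antiproliferative activity, read by MTT assay, with a stated time of 96 h; a lower number here means a stronger inhibitor, a higher number a weaker inhibitor. Compound 2 `Nc1nccn2c(-c3ccc(O)c(O)c3)cnc12` reaches only a limit of > 10000 nM in this assay. Compound 3 `CNc1nccn2c(-c3ccc(OC)c(OC)c3)cnc12` likewise reaches only a limit of > 10000 nM in this assay. On the numbers shown, compound 2 therefore stands at the limit itself, not at a value, and this holds for two of the three results given, namely compound 2 and compound 3 (the limit of > 10000 nM in this assay, at which 2 of the 3 values shown sit).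

Compound 4 `CNc1nccn2c(-c3ccc(O)c(O)c3)cnc12` has not yet been measured. Its change from compound 2 is methyl in place of hydrogen on a nitrogen on an aromatic ring. For the measured compounds named here, since no step between measured compounds is available, the expectation for this assay rests on the limit of compound 3, which carries the same methylamino group and sits at the limit (the limit of > 10000 nM in this assay, at which 2 of the 3 values shown sit). The estimated step that the limit leaves unreadable from compound 2 to compound 4 is expected to be none beyond the scatter. Compound 4 is therefore expected to give about 20000 nM in this assay, in a range from 6000 nM to 60000 nM, and most likely to be reported again as a limit only.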

Compound 4, half-maximal inhibitory concentration: > 10000 nM
Compound 4 was reported as a limit; the forecaster's own chance of this, stated with the estimate: 85%; the middle value does not contradict the limit.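

No step can be read from compound 2 to compound 4, as both results are limits: the limit of > 10000 nM in this assay, at which 3 of the 4 values shown sit.

The compounds shown leave open what methyl in place of hydrogen on a nitrogen on an aromatic ring does when a compound gives a value rather than a limit.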